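Removing one chloro from the core of compound 2

The compounds below may be only part of what the source reports. "The series", "measured", "known", "first", "only" and "open" are said of these compounds alone.

Measured so far:
- In a functional assay on OVCAR-8 cells (Homo sapiens) for cytotoxicity, read by sulforhodamine B assay, with a stated time of 48 h (a lower number here means that less compound is tolerated, a higher number that more compound is tolerated), compound 1, `ClCc1ccccc1Cn1cnc2c(Cl)ncnc21`, gives 20400 nM.
- In this assay compound 2, `ClCc1ccc(Cn2cnc3nc(Cl)nc(Cl)c32)cc1`, gives 8310 nM.

Of these two numbers, compound 2 stands lowest: compound 1 sits higher, and that gap lies beyond the usual scatter of repeated measurements, so compound 2 is the one of which the cells tolerate less. The two compounds differ in more than one place, so nothing can be said about which part of the change drives the gap.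

Compound 3, `ClCc1ccc(Cn2cnc3ncnc(Cl)c32)cc1`, has not yet been measured. It differs from compound 2 in one place: hydrogen in place of chloro on an aromatic carbon. Within the data shown here, no pair of measured compounds shows this change on its own, so there is no measured step to lean on. The expectation is that taking away the chloro will raise the number in this assay, meaning the cells tolerate more of compound 3 than of compound 2, by a step probably just beyond the scatter.

Compound 3 is therefore expected to give about 18000 nM, with a plausible range from 7000 nM to 50000 nM. That estimate amounts to an expected step of a 2.2-fold higher number from compound 2 to compound 3 (0.34 log units; beyond the scatter).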

Compound 3, concentration lethal to 50% of the cells: 56200 nM
Estimate against measurement, compound 3: 3.1-fold (0.49 log units) below, outside the stated range (above it).
By their numbers in this assay, from the lowest: compound 2; then compound 1; then compound 3.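

Among these compounds, for the first time a single change can be read on its own: in this assay, hydrogen in place of chloro on the aromatic carbon between two ring nitrogen atoms gives a 6.8-fold higher number from compound 2 to compound 3 (0.83 log units; beyond the scatter). With the rest of the structure held the same, the loss of this one chlorine atom is enough to move the number well beyond the scatter, so the cells tolerate less of the compound that carries the chloro at this position. The data offer no measurement that accounts for this step, so the reason for it remains unknown.

From the compounds shown here alone, only chloro and hydrogen have been seen at this position, so it remains open whether an amine, a methoxy group or a methyl group there would give a number nearer to that of compound 2 or of compound 3. The chloro that remains on the core of compound 3 has also not been tested by a one-place change, so replacing it with hydrogen or an amine could show whether it matters as much as the chloro lost here.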